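Swapping Naphthyl for Dichlorophenyl in an Aortic Inhibition Series

The source may hold more compounds than are shown below. What is called first, only, known or untested is meant among the compounds shown, and "the series" means these compounds.

Compound 1 `COc1nc(-c2cc3ccccc3o2)cc(-c2ccc3ccccc3c2)c1C#N` and compound 2 `CCOc1nc(-c2cc3ccccc3o2)cc(-c2ccc3ccccc3c2)c1C#N` share one core and differ only in the group on the oxygen bound to the aromatic ring. In a functional assay on aorta (strain Wistar) for inhibition, with Thoracic aorta (Rattus norvegicus) as the target (a lower number here means a stronger inhibitor, a higher number a weaker inhibitor), compound 1 gives 320000 nM, and compound 2 gives 423000 nM. Going by the values given here, the single step between them, a 1.3-fold higher number from compound 1 to compound 2 (0.12 log units; within the scatter), is a change of methyl for hydrogen on a saturated chain carbon bound to that oxygen, so compound 2 stands beside compound 1 with nothing separating them beyond the scatter.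

Compound 3 `CCOc1nc(-c2cc3ccccc3o2)cc(-c2ccc(Cl)cc2Cl)c1C#N` is the next step from compound 2: 2,4-dichlorophenyl in place of naphthalen-2-yl on an aromatic carbon. No measured step among these compounds touches this part of the structure, and the only step in hand, a 1.3-fold higher number from compound 1 to compound 2 (0.12 log units; within the scatter), lies elsewhere and is small. With no guidance from the numbers, compound 3 is expected to stay close to compound 2, a step of a 1.1-fold lower number from compound 2 to compound 3 (0.02 log units; within the scatter) in this assay. The estimate for compound 3 is therefore 400000 nM, with a range from 150000 nM to 1000000 nM.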

Compound 3, half-maximal inhibitory concentration: 442000 nM
Beside the measured number, compound 3's estimate is 1.1-fold (0.04 log units) below it; measured number inside the range.
By their numbers in this assay, from the lowest: compounds 1, 2 and 3 (each within the scatter of the next).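

Going by these compounds alone, at the aromatic carbon opposite the ring nitrogen, the earlier compounds offered no reading, and this step gives the first one: 2,4-dichlorophenyl in place of naphthalen-2-yl gives a 1.0-fold higher number from compound 2 to compound 3 (0.02 log units; within the scatter) in this assay. The exchange of two six-membered aromatic rings for one carrying two chlorine atoms therefore leaves compound 2 and compound 3 indistinguishable in this assay, so both aryl groups are compatible with the shared core at this position. Nothing available accounts for this result.

The compounds shown leave open whether a group of another kind on this carbon, such as an amine or a carboxylic acid, would separate from these values. They also leave open what replacing the 1-benzofuran-2-yl group or the cyano group would do, since both stay fixed throughout.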